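The source may report more compounds than this note shows. Statements on the series, on what has been measured and on what is new or still open speak of the compounds shown alone.

Compound 1 `Cc1c(F)c(Oc2cccc(C(=N)N)c2)nc(Oc2cccc(C(=O)O)c2)c1F` is the starting point of this account. In an assay on isolated protein for inhibition of serine protease 1 (Bos taurus) (a higher number here means a weaker inhibitor, a lower number a stronger inhibitor), compound 1 gives > 5000 nM, which is a limit of the assay rather than a number; its value is the one that rests at the limit of > 5000 nM in this assay, at which 1 of the 3 values shown sits. Compound 2 `Cc1c(F)c(Oc2cccc(NS(C)(=O)=O)c2)nc(Oc2cccc(C(=N)N)c2)c1F` gives 1900 nM in this assay, and compound 3 `Cc1c(F)c(Oc2cccc(CCC(=O)N(C)C)c2)nc(Oc2cccc(C(=N)N)c2)c1F` gives 4900 nM. Measured against the limit of compound 1, an at least 2.6-fold lower number from compound 1 to compound 2 (0.42 log units; beyond the scatter), whereas an at least 1.0-fold lower number from compound 1 to compound 3 (0.00 log units; that floor lies within the scatter). Compound 4 `Cc1c(F)c(Oc2cccc(C(=N)N)c2)nc(Oc2cccc([S+]([O-])N(C)C)c2)c1F` carries a group of 5 heavy atoms (2 carbon, 1 nitrogen, 1 oxygen, 1 sulfur; no ring) in place of a group of 3 heavy atoms (1 carbon, 2 oxygen; no ring), on an aromatic carbon. The two steps away from compound 1 frame what this exchange can do: a modest gain at best, or no change beyond the scatter. Compound 4 is therefore expected to show an at least 2.0-fold lower number from compound 1 to compound 4 (0.30 log units; that floor lies within the scatter). The estimate for compound 4 in this assay is 2500 nM, with a range from 1000 nM to 8000 nM.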

Compound 4, inhibition constant: 2400 nM
Beside the measured number, compound 4's estimate is 1.0-fold (0.02 log units) above it; the measured number falls inside the stated range.
By their numbers in this assay, from the lowest: compounds 2 and 4 (each within the scatter of the next); then compound 3. At a limit, above all of these: compound 1.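

In this assay, the exchange of carboxy on this aromatic carbon for the new group gives an at least 2.0-fold lower number from compound 1 to compound 4 (0.31 log units; beyond the scatter). Compound 1 stands only at a limit of the assay: the limit of > 5000 nM in this assay, at which 1 of the 4 values shown sits. The same group gives a 2.0-fold lower number from compound 3 to compound 4 (0.31 log units; beyond the scatter), while a 1.3-fold higher number from compound 2 to compound 4 (0.10 log units; within the scatter), so in this position it cannot be told apart from methanesulfonamido.

The compounds shown leave open whether a primary amine or a longer sulfonamide chain at this place would lower the number further in this assay.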